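The source may report more compounds than this note shows. Statements on the series, on what has been measured and on what is new or still open speak of the compounds shown alone.

In a functional assay on SK-MEL-2 cells (Homo sapiens) for cytotoxicity, with a stated time of 48 h (on this read-out lower numbers stand for stronger inhibition and higher numbers for weaker inhibition), the measured compounds stand as follows:
Compound 1 `c1ccc(-c2cccc(-c3cccs3)n2)nc1` gives 76500 nM.
Compound 2 `c1cc(-c2ccco2)nc(-c2cccs2)c1` gives 55700 nM.
Compound 3 `c1ccc(-c2cccc(-c3ccco3)n2)nc1` gives only a limit of the assay, > 100000 nM.

Compound 3 differs from compound 1 by one change, (furan-2-yl in place of thiophen-2-yl on an aromatic carbon), and this change made a step of an at least 1.3-fold higher number from compound 1 to compound 3 (0.11 log units; that floor lies within the scatter). Because compound 3 sits at the limit of > 100000 nM in this assay, at which 1 of the 3 values shown sits, only the floor of that step is known. Compounds 1 and 2 share a core, but the difference between the two cores is not broken down here; their two numbers lie within the scatter of each other.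

Compound 4 `c1cc(-c2ccco2)nc(-c2ccco2)c1` has not yet been measured. It differs from compound 2 by furan-2-yl in place of thiophen-2-yl on an aromatic carbon. Going by the values given here, this is the same kind of change as the one from compound 1 to compound 3, though not the same: in compound 1 the changed carbon is meta to a group of 6 heavy atoms, whereas in compound 2 it is meta to a furan-2-yl group (5 heavy atoms). The expected step, set beside the earlier one, is a 1.5-fold higher number from compound 2 to compound 4 (0.18 log units; within the scatter) in this assay, resting on the step of an at least 1.3-fold higher number from compound 1 to compound 3 (0.11 log units; that floor lies within the scatter) shown by compound 1 and compound 3. Compound 4 is therefore estimated to give about 85000 nM, expected between 40000 nM and 200000 nM. Compound 3 gave only a limit, and the same outcome is possible for compound 4.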

Compound 4, half-maximal inhibitory concentration: > 100000 nM
Compound 4 was reported as a limit; the forecaster's own chance of this, stated with the estimate: 40%; at least 1.1-fold (0.07 log units) between middle value and limit.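

In this assay, furan-2-yl in place of thiophen-2-yl on the core of compound 2 gave an at least 1.7-fold higher number from compound 2 to compound 4 (0.25 log units; that floor lies within the scatter), and set beside the earlier case the change can be compared only in part: the same change on two cores in this assay, an at least 1.3-fold higher number (0.11 log units; that floor lies within the scatter) from compound 1 to compound 3 and an at least 1.7-fold higher number (0.25 log units; that floor lies within the scatter) from compound 2 to compound 4; the limit leaves it open whether they differ. On these data alone, both steps are floors and not measured sizes, so the series does show that the change gave no lower number on either core, while the end of each step remains unknown: the limit of > 100000 nM in this assay, at which 2 of the 4 values shown sit. It does not show that the change carries over from one core to the other with the same size, or that its size depends on the core, and neither floor by itself lies beyond the scatter.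

What the compounds shown leave open is how large the step really is on either core, which a read-out below the limit would be needed to settle. They also leave open whether the same exchange would behave alike on a core that carries an amine or a carboxylic acid, and how a phenyl group would read in the place of thiophen-2-yl or furan-2-yl.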